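The source may report more compounds than this note shows. Statements on the series, on what has been measured and on what is new or still open speak of the compounds shown alone.

Compound 1 `CCc1ccc2[nH]c(=O)c(CN(Cc3ccc(F)cc3)Cc3ccc(C(C)(C)C)cc3)cc2c1` and compound 2 `CCCc1ccc2[nH]c(=O)c(CN(Cc3ccc(F)cc3)Cc3ccc(C(C)(C)C)cc3)cc2c1` share one core and differ only where (methyl in place of hydrogen on a saturated chain carbon, two bonds along the chain from an aromatic carbon). In a toxicity assay on MDCK cells (Canis lupus familiaris) for cytotoxicity, read by crystal violet staining, with a stated time of 48 h (a lower number here means that less compound is tolerated, a higher number that more compound is tolerated), compound 1 gives > 33000 nM, which is a limit of the assay rather than a number, as the limit of > 33000 nM in this assay, at which 1 of the 3 values shown sits, records. In this assay compound 2 gives 8400 nM. Between the two there is an at least 3.9-fold lower number from compound 1 to compound 2 (0.59 log units; beyond the scatter). Compound 3 `CCCOc1ccc(CN(Cc2ccc(C(C)(C)C)cc2)Cc2cc3cc(C)ccc3[nH]c2=O)cc1` is built on another core; the difference between the two cores is not broken down here. In this assay compound 3 gives > 5000 nM, again a limit of the assay and not a number, as the limit of > 5000 nM in this assay, at which 1 of the 3 values shown sits, records. Compound 4 `CCCCOc1ccc(CN(Cc2ccc(C(C)(C)C)cc2)Cc2cc3cc(C)ccc3[nH]c2=O)cc1` is compound 3 with methyl in place of hydrogen on a saturated chain carbon, three bonds along the chain from an oxygen on an aromatic ring. This is the same kind of change as in the first pair, though not the same: there the added methyl sat two bonds along the chain from an aromatic carbon, here it sits three bonds along the chain from an oxygen on an aromatic ring. A lowering of similar size is expected, namely a number no higher from compound 3 to compound 4 (the limit leaves the size open), because the measured pair showed an at least 3.9-fold lower number from compound 1 to compound 2 (0.59 log units; beyond the scatter). Compound 4 is therefore estimated at 5000 nM, most likely between 2000 nM and 20000 nM.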

Compound 4, half-maximal cytotoxic concentration: > 5000 nM
Compound 4: a limit, no number; the forecaster's own chance of this, stated with the estimate: 35%; the middle value sits exactly at the limit.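

For the compounds shown here, compound 3 and compound 4 both rest at the same limit of the assay rather than at a number, so no step from one to the other can be read: the limit of > 5000 nM in this assay, at which 2 of the 4 values shown sit. The compounds shown leave open whether going from propyl to butyl on this chain changes how much compound is tolerated in this assay.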